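Adding isopropyl to a sulfonamide acid core

A few compounds are considered here, and "the series" means these few. Any claim that something is new, unique, unknown or untested is made for them only; others in the source may bear on it.

Measured in a functional assay (thoracic aorta) for inhibition, with Rattus norvegicus as the target; a lower number here means a stronger inhibitor, a higher number a weaker inhibitor:
- compound 1 `O=C(O)c1cc(CCCCNS(=O)(=O)c2ccccc2)c2cccccc1-2`: 570 nM
- compound 2 `CC(C)c1ccc2c(CCCNS(=O)(=O)c3ccccc3)cc(C(=O)O)c-2cc1`: 4800 nM
- compound 3 `CC(C)c1ccc2c(CCCCNS(=O)(=O)c3ccccc3)cc(C(=O)O)c-2cc1`: 70 nM

Among these three numbers, compound 1 at 570 nM stands second highest. Compound 2 at 4800 nM lies on the higher side of it, and compound 3 at 70 nM on the lower side.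

The next compound in view, compound 4 `CC(C)c1cccc2c(CCCCNS(=O)(=O)c3ccccc3)cc(C(=O)O)c-2c1`, departs from compound 1 by one change: isopropyl in place of hydrogen on an aromatic carbon. The change is isopropyl in place of hydrogen on an aromatic carbon of the seven-membered ring.

Among the compounds with values here, one measured step bears on it, the same exchange of hydrogen for isopropyl: an 8.1-fold lower number from compound 1 to compound 3 (0.91 log units; beyond the scatter). Within the data shown here, it is only a partial guide, since the isopropyl of compound 4 sits on a different aromatic carbon from that of compound 3, and no measured compound shows what that difference does in this assay. A lower number is therefore expected, though a smaller drop than in the measured step. The expected change is a 3.8-fold lower number from compound 1 to compound 4 (0.58 log units; beyond the scatter). For compound 4 the estimated value is 150 nM, with an expected range from 40 nM to 600 nM.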

Compound 4, half-maximal inhibitory concentration: 3100 nM
Compound 4: middle estimate off by 21-fold (1.32 log units), on the low side; the whole stated range lies below it.
By their numbers in this assay, from the lowest: compound 3; then compound 1; then compounds 4 and 2 (each within the scatter of the next).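

In this assay, the exchange of hydrogen for isopropyl on an aromatic carbon of the seven-membered ring has no single direction: here it gives a 5.4-fold higher number from compound 1 to compound 4 (0.74 log units; beyond the scatter) while the same exchange on a different aromatic carbon gives an 8.1-fold lower number from compound 1 to compound 3 (0.91 log units; beyond the scatter) in the same assay. The earlier compounds shown here carried the isopropyl on one carbon only, so they could not show that the result of this change depends on which aromatic carbon holds the group. No supporting information accounts for the contrast between the two carbons.

As far as these compounds go, whether a smaller group such as methyl or a larger one such as tert-butyl would fare differently on this carbon remains open. So does what isopropyl would do on the other aromatic carbons of the ring.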